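From 4-butoxyphenyl to 3-chlorophenyl on a shared core

The compounds below may be only part of what the source reports. "The series", "measured", "known", "first", "only" and "open" are said of these compounds alone.

Measured compounds in a functional assay on MDA-MB-231 cells (Homo sapiens) for antiproliferative activity, read by MTT assay, with a stated time of 24 h (a higher number here means a weaker inhibitor, a lower number a stronger inhibitor), are these:
- compound 1 `O=C(NNc1ccccc1Cl)c1ccccc1NS(=O)(=O)c1cnc(O)nc1O` gives 18900 nM here
- compound 2 `O=C(NNc1ccc(F)cc1)c1ccccc1NS(=O)(=O)c1cnc(O)nc1O` gives > 20000 nM here, which is a limit and not a number
- compound 3 `CCCCOc1ccc(C(=O)NNC(=O)c2ccccc2NS(=O)(=O)c2cnc(O)nc2O)cc1` gives 6830 nM here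

Compound 3, at 6830 nM, has the lowest of the numbers shown, and the gap up to compound 1 lies beyond the scatter. Compound 4 `O=C(NNC(=O)c1ccccc1NS(=O)(=O)c1cnc(O)nc1O)c1cccc(Cl)c1` differs from compound 3 by 3-chlorophenyl in place of 4-butoxyphenyl on a carbonyl carbon.

For the measured compounds named here, the one measured step is an at least 1.0-fold higher number from compound 1 to compound 2 (0.02 log units; that floor lies within the scatter), and it sits on an amine nitrogen, not on this carbonyl carbon. The end point of compound 2 is the limit of > 20000 nM in this assay, at which 1 of the 3 values shown sits, so that step is only a floor. It therefore gives no direct size for this change. The nearest guide is compound 1, a 2-chlorophenyl compound, at 18900 nM on the higher side, so a move towards a higher number is expected. The expected step is a 1.9-fold higher number from compound 3 to compound 4 (0.28 log units; within the scatter) in this assay as a rough guide. Compound 4 is estimated at 13000 nM with an expected range from 5000 nM to 25000 nM in that read-out.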

Compound 4, half-maximal inhibitory concentration: 4420 nM
Estimate against measurement, compound 4: 2.9-fold (0.47 log units) above, outside the stated range (below it).
By their numbers in this assay, from the lowest: compounds 4 and 3 (each within the scatter of the next); then compound 1. At a limit, above all of these: compound 2.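

Swapping 4-butoxyphenyl for 3-chlorophenyl on a carbonyl carbon gives a 1.5-fold lower number from compound 3 to compound 4 (0.19 log units; within the scatter) in this assay and so shows that, in this pair, the two groups cannot be told apart at this position and the butoxy chain is not required for this level of activity. The comparison with an aryl group directly on the amine nitrogen is clearer, since (3-chlorophenyl)carbonyl in place of 2-chlorophenyl gives a 4.3-fold lower number from compound 1 to compound 4 (0.63 log units; beyond the scatter) and thus links the added carbonyl to a lower number. The step of an at least 4.5-fold lower number from compound 2 to compound 4 (0.65 log units; beyond the scatter) points the same way but is only a floor, set by a limit and not a number: the limit of > 20000 nM in this assay, at which 1 of the 4 values shown sits.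

As far as these compounds go, whether the chlorine needs this place on the ring remains open, as a 4-chlorophenyl group on the carbonyl carbon would test. So does the effect of an amine or a carboxylic acid on that ring.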